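This account rests on a few compounds, and the source may have more. Where it says the series, first, only, none or still open, it means among the compounds named here.

Compound 1 `CNC(=N)Nc1nc(-c2ccc(OC)cc2)c(-c2ccc(OC)cc2)s1` gives 1.2 uM in a functional assay (aorta) with Rattus norvegicus as the target; a higher number here means that more compound is needed for the effect, a lower number that less compound is needed.
Compound 2 `COc1ccc(-c2nc(/N=C(\N)N(C)C)sc2-c2ccc(OC)cc2)cc1` gives 4.8 uM in this assay.

Within the data shown here, compound 2 thus holds the higher of the two numbers; its only neighbour is compound 1, with a 4.0-fold higher number from compound 1 to compound 2 (0.60 log units; beyond the scatter). Compound 3 `COc1ccc(-c2nc(CNC(=O)c3cccnc3)sc2-c2ccc(OC)cc2)cc1` carries a group of 10 heavy atoms (7 carbon, 2 nitrogen, 1 oxygen; one six-membered aromatic ring with 1 hetero atom) in place of a group of 6 heavy atoms (3 carbon, 3 nitrogen; no ring), on an aromatic carbon. Among the measured compounds shown here, the single measured step, a 4.0-fold higher number from compound 1 to compound 2 (0.60 log units; beyond the scatter), also exchanges groups on that aromatic carbon and is modest, but neither of its groups resembles the (((pyridin-3-yl)carbonyl)amino)methyl group entering here, so it bears on this change only loosely. The expected step is a 1.5-fold higher number from compound 2 to compound 3 (0.16 log units; within the scatter), toward a higher number and somewhat beyond the scatter. Compound 3 is therefore estimated at 7 uM, within a range from 1.5 uM to 30 uM.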

Compound 3, concentration for half-maximal effect: 8.2 uM
Estimate against measurement, compound 3: 1.2-fold (0.07 log units) below; low and high end bracket the measured number.
By their numbers in this assay, from the lowest: compound 1; then compounds 2 and 3 (each within the scatter of the next).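

In this assay, the ringless group on this aromatic carbon gives way to the larger (((pyridin-3-yl)carbonyl)amino)methyl group, which brings in a six-membered aromatic ring, and the result is a 1.7-fold higher number from compound 2 to compound 3 (0.23 log units; within the scatter), so this exchange leaves no readable change. Against the group of compound 1, the same entering group gives a 6.8-fold higher number from compound 1 to compound 3 (0.83 log units; beyond the scatter), which lies beyond the scatter and leaves compound 1 with the lowest number of the three. Nothing shown here explains either step.

Going by these compounds, it remains open how a plain amine or a carboxylic acid on this carbon would compare. On these data alone, it also remains open whether a longer chain leading to the pyridine ring would change the number.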